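Chloro for hydrogen on a pyrazole-fused anticancer scaffold

The compounds below may be only part of what the source reports. "The series", "measured", "known", "first", "only" and "open" are said of these compounds alone.

Compound 1 `N#Cc1c(-c2nnc(-c3nn(-c4ccccc4)c(-c4ccccc4)c3C#N)c3nn(-c4ccccc4)cc23)nn(-c2ccccc2)c1-c1ccccc1`: 7460 nM
Compound 2 `N#Cc1c(-c2nnc(-c3nn(-c4ccccc4)c(-c4ccccc4)c3C#N)c3nn(-c4ccc(Cl)cc4)cc23)nn(-c2ccccc2)c1-c1ccccc1`: 43800 nM
Compound 3 `N#Cc1c(-c2nnc(-c3ccccc3)c3nn(-c4ccccc4)cc23)nn(-c2ccccc2)c1-c1ccccc1`: 63000 nM

Three compounds were tested in a functional assay on OVCAR-4 cells (Homo sapiens) for inhibition, read by sulforhodamine B assay, with a stated time of 48 h; a higher number here means a weaker inhibitor of growth, a lower number a stronger inhibitor of growth. Compound 1 gives 7460 nM. Compound 2 carries chloro in place of hydrogen on an aromatic carbon, and the number moves a 5.9-fold higher number from compound 1 to compound 2 (0.77 log units; beyond the scatter). Compound 3 has a different core; how its core differs from that of compound 1 is not broken down here. In this assay compound 3 gives 63000 nM, which puts it near compound 2 and well apart from compound 1.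

The unmeasured compound 4 `N#Cc1c(-c2nnc(-c3ccccc3)c3nn(-c4ccc(Cl)cc4)cc23)nn(-c2ccccc2)c1-c1ccccc1` stands to compound 3 as compound 2 stands to compound 1: it carries chloro in place of hydrogen on an aromatic carbon, at a place described in the same words. For the measured compounds named here, the only guide to the size of the step is the measured pair, where the change gave a 5.9-fold higher number from compound 1 to compound 2 (0.77 log units; beyond the scatter). On that basis, compound 4 is expected to move a 4.0-fold higher number from compound 3 to compound 4 (0.60 log units; beyond the scatter) in this assay, with the caveat that compound 3 already starts high and a measured number may not be reached. The estimate for compound 4 is 250000 nM, expected to fall between 70000 nM and 700000 nM.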

Compound 4, concentration for 50% growth inhibition: 7660 nM
Compound 4: the middle estimate sits 33-fold (1.51 log units) above what was measured; the measured number lies below the stated range.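

In this assay, the change from phenyl to 4-chlorophenyl gives an 8.2-fold lower number from compound 3 to compound 4 (0.92 log units; beyond the scatter), so the swap that weakened growth inhibition on the core of compound 1 strengthens it on the core of compound 3. The two results point in opposite directions, and the gap between them is larger than repeated measurements would explain: the same change on two cores in this assay, a 5.9-fold higher number (0.77 log units; beyond the scatter) from compound 1 to compound 2 and an 8.2-fold lower number (0.92 log units; beyond the scatter) from compound 3 to compound 4, 48-fold (1.68 log units) apart, beyond the scatter of two such steps. This shows that neither the size nor the direction of this change carried from one core to the other here, but two pairs cannot show what causes the reversal or predict the result on a third core.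

The compounds shown leave open whether a fluoro group, a methoxy group or an amine at the same place would also behave differently on the two cores. They also leave open which part of the difference between the core of compound 1 and the core of compound 3 governs the outcome.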